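A few compounds are considered here, and "the series" means these few. Any claim that something is new, unique, unknown or untested is made for them only; others in the source may bear on it.

Measured compounds:
- compound 2, `COc1cc(Oc2cccc(Nc3ccccc3)c2)cc(OC)c1CN[C@H](C)c1ccccc1`, 18700 nM
- compound 1, `COc1ccc(CCCNCc2c(OC)cc(Oc3ccc(Nc4ccccc4)cc3)cc2OC)cc1`, 14600 nM
- compound 3, `COc1ccc([C@@H](C)NCc2c(OC)cc(Oc3cccc(Nc4ccccc4)c3)c(OC)c2OC)cc1`, 8250 nM

In a functional assay on SW-620 cells (Homo sapiens) for inhibition, read by MTT assay, with a stated time of 72 h (a lower number here means a stronger inhibitor, a higher number a weaker inhibitor), compound 2 gives 18700 nM, the highest of the three numbers. Compound 1 gives 14600 nM, a number that lies within the usual scatter of that of compound 2. Compound 3 gives 8250 nM, a lower number, and this gap to compound 2 goes beyond the scatter. No pair of these compounds differs in a single place, so no measured step guides the change that leads to compound 4, `COc1cc(Oc2cccc(Nc3ccccc3)c2)cc(OC)c1CNCc1ccc(O)cc1`. The change is 4-hydroxybenzyl in place of 1-phenylethyl on an amine nitrogen. Among the compounds with values here, with no matched step to rest on, only a modest step is expected, with no firm direction, and the number for compound 4 is estimated to stay near that of compound 2 in this assay. Compound 4 is therefore expected to give about 15000 nM, within a range of 6000 nM to 40000 nM. This estimate corresponds to a 1.2-fold lower number from compound 2 to compound 4 (0.10 log units; within the scatter), a step expected to fall within the scatter.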

Compound 4, half-maximal inhibitory concentration: 7940 nM
Estimate against measurement, compound 4: 1.9-fold (0.28 log units) above; measured number inside the range.
By their numbers in this assay, from the lowest: compounds 4, 3, 1 and 2 (each within the scatter of the next, the first and the last beyond it).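

In this assay, the group on this amine nitrogen proved able to move the number beyond the scatter: 4-hydroxybenzyl in place of 1-phenylethyl gave a lower number (a 2.4-fold lower number from compound 2 to compound 4 (0.37 log units; beyond the scatter)). The heavy-atom count stayed the same, while the defined stereocentre left and a hydrogen-bond donor and acceptor entered, and this combined change brought no loss at this position. No measurement at hand explains the step.

The compounds shown leave open whether the lower number follows the hydroxyl group, the loss of the methyl branch of 1-phenylethyl, or both, as these changed together. A plain benzyl group on the same nitrogen would separate the two, and a 4-methoxybenzyl or 4-aminobenzyl group would show whether the hydroxyl itself can be replaced.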